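The source may hold more compounds than are shown below. What is called first, only, known or untested is meant among the compounds shown, and "the series" means these compounds.

Of the compounds shown here, three with a shared core have been tested in a functional assay on NCI-H460 cells (Homo sapiens) for cytotoxicity, read by sulforhodamine B assay, with a stated time of 48 h, tested at 0.01 uM; on this read-out higher numbers stand for a weaker effect at the one concentration tested and lower numbers for a stronger effect. Compound 1 `COc1cc(-c2cc(/C=C/C(=O)c3ccc(N)cc3)[nH]n2)cc(OC)c1OC` gives 102%, compound 2 `COc1cc(-c2cc(/C=C/C(=O)c3ccc(Cl)c(Cl)c3)[nH]n2)cc(OC)c1OC` gives 105%, and compound 3 `COc1ccc(C(=O)/C=C/c2cc(-c3cc(OC)c(OC)c(OC)c3)n[nH]2)cc1OC` gives 103%. All three differ only in the ring on the carbonyl carbon, and every step among them stays within the scatter: a number 3 percentage points higher from compound 1 to compound 2 (within the scatter), a number 1 percentage points higher from compound 1 to compound 3 (within the scatter) and a number 2 percentage points lower from compound 2 to compound 3 (within the scatter). Compound 3 therefore stands among the others with no separation that the measurement can resolve, and at this concentration none of the three shows a detectable effect.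

Compound 4 `COc1ccc(C(=O)/C=C/c2cc(-c3cc(OC)c(OC)c(OC)c3)n[nH]2)cc1` is not yet measured. It differs from compound 3 in one place: hydrogen in place of methoxy on an aromatic carbon. Among the measured compounds shown here, no measured step removes a methoxy from this ring, so the closest guides are the exchanges of the whole ring on the carbonyl carbon, none of which moved the number beyond the scatter. A step of no change at the digits printed from compound 3 to compound 4 (within the scatter) is expected, that is, no change beyond the scatter. Compound 4 is estimated at 103%, within 92% to 114%.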

Compound 4, a percentage reported as activity, at one concentration (the size of the read-out at that concentration, not a potency): 103%
Compound 4: middle estimate and measured number agree at the digits printed, and the stated range covers the measured number.
By their numbers in this assay, from the lowest: compounds 1, 3, 4 and 2 (each within the scatter of the next).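

Unlike the earlier steps, which exchanged the whole ring on the carbonyl carbon, this one takes a single methoxy off that ring, and in this assay the result is flat (no change at the digits printed from compound 3 to compound 4 (within the scatter)). The 4-methoxyphenyl ring also cannot be told apart from the other two rings at this one low concentration (a number 2 percentage points lower from compound 2 to compound 4 (within the scatter); a number 1 percentage points higher from compound 1 to compound 4 (within the scatter)), so neither removing the methoxy nor exchanging the ring produces a step that the measurement can resolve. No further measurement is available that could explain this flat result.

The compounds shown leave open whether a hydroxyl or a fluorine in place of this methoxy would move the number. They also leave open whether these four compounds, none with a detectable effect here, would separate at a higher concentration.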